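This account rests on a few compounds, and the source may have more. Where it says the series, first, only, none or still open, it means among the compounds named here.

Compound 1 `CCn1nnc(-c2sc(-c3ccc(Cl)cc3)nc2O)n1`, compound 2 `CCOC(=O)c1sc(-c2ccc(F)cc2)nc1O` and compound 3 `CCOC(=O)c1sc(-c2ccc(Cl)cc2)nc1O` were all tested in an assay on HEK293 cells for inhibition of transient receptor potential cation channel subfamily M member 8 (Homo sapiens), read by FLIPR, with stated times of 5 min and 3 min; on this read-out higher numbers stand for weaker inhibition and lower numbers for stronger inhibition. Compound 1 gives 7550 nM, compound 2 gives 80 nM and compound 3 gives 550 nM. Compound 2 and compound 3 share a core, and the step of a 6.9-fold lower number from compound 3 to compound 2 (0.84 log units; beyond the scatter) comes from a single change, (fluoro in place of chloro on an aromatic carbon). Compound 1 rests on a different core, and the difference between the two cores is not broken down here.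

Compound 4 `CCn1nnc(-c2sc(-c3ccc(F)cc3)nc2O)n1` has not yet been measured. Going by the values given here, it differs from compound 1 by fluoro in place of chloro on an aromatic carbon, which is the same change as the one from compound 3 to compound 2, at the same place. That earlier change appears only once among the measured compounds, so how far it carries over to the other core is uncertain. Still, because compound 2 and compound 3 show the step of a 6.9-fold lower number from compound 3 to compound 2 (0.84 log units; beyond the scatter), a step of similar direction is expected for compound 4, estimated as a 5.0-fold lower number from compound 1 to compound 4 (0.70 log units; beyond the scatter). Compound 4 is therefore expected to give about 1500 nM, most likely between 500 nM and 5000 nM.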

Compound 4, half-maximal inhibitory concentration: 286 nM
For compound 4 the middle estimate is 5.2-fold (0.72 log units) above the measured one; the measured number lies below the stated range.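

On the core of compound 1, fluoro in place of chloro gives a 26-fold lower number from compound 1 to compound 4 (1.42 log units; beyond the scatter) in this assay, so the change lowers the number here as it does on the core shared by compound 2 and compound 3. The direction therefore carries over from one core to the other, but the size does not, and the two steps stand further apart than repeated measurements would explain: the same change on two cores in this assay, a 6.9-fold lower number (0.84 log units; beyond the scatter) from compound 3 to compound 2 and a 26-fold lower number (1.42 log units; beyond the scatter) from compound 1 to compound 4, 3.8-fold (0.58 log units) apart, beyond the scatter of two such steps. Going by these compounds alone, with only two pairs of compounds, this shows that the size of the step depends on the core, but it does not show the reason for that difference or predict the step on any third core.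

On these data alone, it remains open how a methyl or a methoxy group on the same aromatic carbon would compare with fluoro and chloro on either core. Also open, as far as these compounds go, is whether a carboxylic acid or an amide in place of the ethyl ester would preserve the low number of compound 2.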